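Furanylmethylamino series: cyclopentyl to cyclohexyl

A few compounds are considered here, and "the series" means these few. Any claim that something is new, unique, unknown or untested is made for them only; others in the source may bear on it.

Measured so far in an ADME assay on J774.A1 cells (Mus musculus) for inhibition, read by MTT assay, with a stated time of 72 h; a higher number here means that more compound is needed for the effect, a lower number that less compound is needed
compound 1 `CC(C)Nc1nc(NCc2ccco2)c2ccccc2n1` gives 17000 nM
compound 2 `CNc1nc(NCc2ccco2)c2ccccc2n1` gives "not determined" (no result reported)
compound 3 `c1coc(CNc2nc(NC3CCCC3)nc3ccccc23)c1` gives "not determined" (no result reported)

Only compound 1 carries a number. Compound 3 reads "not determined" (no result reported) in this assay and so has no place on the scale, either against compound 1 or against compound 2, which also lacks a result. No measured step exists in this set, and the effect of changing the amine substituent is therefore not shown by the data.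

Compound 4 `c1coc(CNc2nc(NC3CCCCC3)nc3ccccc23)c1` is compound 3 with cyclohexyl in place of cyclopentyl on a nitrogen on an aromatic ring and the rest of the structure unchanged. With nothing to indicate a direction, no step beyond the usual scatter is expected in this assay for this change. Among the measured compounds shown here, the only anchor is compound 1 at 17000 nM and it sets the level of the estimate. For compound 4 the expected half-maximal effective concentration is 12000 nM with an estimated range from 4000 nM to 35000 nM in this assay.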

Compound 4, half-maximal effective concentration: 5300 nM
Estimate against measurement, compound 4: 2.3-fold (0.35 log units) above; low and high end bracket the measured number.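

In this assay, cyclohexyl in place of isopropyl on a nitrogen on an aromatic ring gives a 3.2-fold lower number from compound 1 to compound 4 (0.51 log units; beyond the scatter). Among the compounds shown here, this is the first measured step at this position, and it shows that the group on this nitrogen can move the number beyond the usual scatter. The cyclopentyl to cyclohexyl change itself cannot be read, since compound 3 has no result, and no supporting data bear on the origin of the step between the isopropyl and cyclohexyl compounds.

As far as these compounds go, with a single step, it remains open whether the lower number tracks ring size, the presence of a ring or the count of carbons. Where a benzyl group, a longer alkyl chain or a chain ending in an amine on this nitrogen would fall on this scale is also open.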